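The source may report more compounds than this note shows. Statements on the series, on what has been measured and on what is new or still open speak of the compounds shown alone.

Values in an ADME assay on MT4 cells (Homo sapiens) for cytotoxicity, read by MTT assay; a higher number here means that more compound is tolerated, a lower number that less compound is tolerated:
- Compound 1 `Cc1cc(C)cc(S(=O)(=O)c2c(C(=O)NCc3ccccc3O)[nH]c3ccc(Cl)cc23)c1`: 23800 nM
- Compound 2 `Cc1cc(C)cc(S(=O)(=O)c2c(C(=O)NCc3cccc(O)c3)[nH]c3ccccc23)c1`: > 5190 nM (a limit)
- Compound 3 `Cc1cc(C)cc(S(=O)(=O)c2c(C(=O)NCc3cccc(O)c3)[nH]c3ccc(Cl)cc23)c1`: 27000 nM

For the measured compounds named here, compound 1 stands level with the only other true number in this assay: a 1.1-fold higher number from compound 1 to compound 3 (0.05 log units; within the scatter). The chloro change gives no size: a step that the limit leaves unreadable from compound 2 to compound 3.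

Compound 4 `Cc1cc(C)cc(S(=O)(=O)c2c(C(=O)NCc3cc(O)ncn3)[nH]c3ccc(Cl)cc23)c1` keeps the core of compound 1 but has 6-hydroxypyrimidin-4-yl in place of 2-hydroxyphenyl on a saturated chain carbon bound to an amide-type nitrogen.

The nearest evidence is the swap of 2-hydroxyphenyl for 3-hydroxyphenyl, a 1.1-fold higher number from compound 1 to compound 3 (0.05 log units; within the scatter). Going by the values given here, no measured compound carries a ring with hetero atoms at this place, so the forecast is loose. The expected change is small, with no clear direction: a 1.1-fold higher number from compound 1 to compound 4 (0.02 log units; within the scatter). For compound 4 the estimated value is 25000 nM, with an expected range of 9000 nM to 70000 nM.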

Compound 4, half-maximal cytotoxic concentration: > 53000 nM
Compound 4: a limit, no number; the forecaster's own chance of this, stated with the estimate: 35%; middle value at least 2.1-fold (0.32 log units) away from the limit.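

In this assay compound 4 gives > 53000 nM, which is a limit and not a number. Placing 6-hydroxypyrimidin-4-yl on this chain carbon gives an at least 2.2-fold higher number from compound 1 to compound 4 (0.34 log units; beyond the scatter), the first sign that a ring with hetero atoms here can be better tolerated than 2-hydroxyphenyl. Starting from 3-hydroxyphenyl, the same kind of swap gives an at least 1.9-fold higher number from compound 3 to compound 4 (0.29 log units; that floor lies within the scatter), so this second comparison is less clear.

As far as these compounds go, how far the true value of compound 4 lies past its limit remains open. Also open, from the compounds shown here alone, is how an amine or a carboxylic acid at this place would compare.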